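The source may report more compounds than this note shows. Statements on the series, on what has been measured and on what is new or still open speak of the compounds shown alone.

Compound 1: `Cc1c(F)c(Oc2cccc(C(=N)N)c2)nc(Oc2cccc(C(=O)O)c2)c1F`, > 5000 nM
Compound 2: `Cc1c(F)c(Oc2cccc(C(=N)N)c2)nc(Oc2cccc(C(=O)N3CCCC3)c2)c1F`, 2800 nM

Both compounds share one core and differ only in the group carried on one of the two phenyl rings. In an assay on isolated protein for inhibition of serine protease 1 (Bos taurus) (a higher number here means a weaker inhibitor, a lower number a stronger inhibitor), compound 1 reaches only the limit of the assay, > 5000 nM, so no exact number is known for it; this is the situation described by the limit of > 5000 nM in this assay, at which 1 of the 2 values shown sits. In this assay compound 2 gives 2800 nM. For the measured compounds named here, the single measured step, an at least 1.7-fold lower number from compound 1 to compound 2 (0.25 log units; that floor lies within the scatter), is therefore known only as a floor, and that floor lies within the scatter.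

Compound 3, `Cc1c(F)c(Oc2cccc(C(=N)N)c2)nc(Oc2cccc(-n3ccnc3)c2)c1F`, has not yet been measured. It differs from compound 1 in one place: 1H-imidazol-1-yl in place of carboxy on an aromatic carbon. Going by the values given here, as in the step to compound 2, the carboxy group is taken away, so the step from compound 1 to compound 2 is the only measured step that bears on this change, and it amounts at best to a floor. For compound 3 a step of comparable kind, an at least 1.6-fold lower number from compound 1 to compound 3 (0.22 log units; that floor lies within the scatter), is therefore expected, downward but not clearly beyond the scatter. Compound 3 is estimated at 3000 nM, with a range from 1000 nM to 10000 nM.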

Compound 3, inhibition constant: 4800 nM
Compound 3: the middle estimate sits 1.6-fold (0.20 log units) below what was measured; low and high end bracket the measured number.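

In this assay, putting 1H-imidazol-1-yl in place of the carboxy group gives an at least 1.0-fold lower number from compound 1 to compound 3 (0.01 log units; that floor lies within the scatter), and a floor this small says almost nothing about how far the number really moves. The step that can be read more firmly is a 1.7-fold higher number from compound 2 to compound 3 (0.23 log units; within the scatter), since both of its compounds have exact numbers: on this aromatic carbon, a five-membered aromatic ring and the (pyrrolidin-1-yl)carbonyl group cannot be told apart in this assay, so the two replacements for the carboxy group give no ranking between them. The true size of the change on leaving the carboxy group stays unknown because compound 1 carries a limit and not an exact number: the limit of > 5000 nM in this assay, at which 1 of the 3 values shown sits.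

The compounds shown leave open whether any group on this aromatic carbon can move the number clearly beyond the scatter. A primary amide, an aminomethyl group or a longer chain ending in an amine would test this, and each could show whether the weak binding seen so far holds for groups of other kinds at this place.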